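Replacing methyl with chloro in compound 2

A few compounds are considered here, and "the series" means these few. Any claim that something is new, unique, unknown or untested is made for them only; others in the source may bear on it.

Measured so far in a functional assay on DU-145 cells (Homo sapiens) for inhibition, read by trypan blue exclusion, with a stated time of 96 h; on this read-out higher numbers stand for weaker inhibition of growth and lower numbers for stronger inhibition of growth:
- compound 1 `Cc1ccc(CS(=O)(=O)/C(=C/c2ccc(Br)cc2)C(=O)c2ccc(Cl)cc2)cc1` gives 25000 nM
- compound 2 `CSc1ccc(/C=C(\C(=O)c2ccc(Cl)cc2)S(=O)(=O)Cc2ccc(C)cc2)cc1` gives 10000 nM
- compound 3 `Cc1ccc(CS(=O)(=O)/C(=C/c2sccc2C)C(=O)c2ccc(Cl)cc2)cc1` gives 25000 nM

Compound 2 has the lowest number of the three, which means the strongest growth inhibition in this small set. Its lead is modest: a 2.5-fold lower number from compound 1 to compound 2 (0.40 log units; beyond the scatter) and a 2.5-fold higher number from compound 2 to compound 3 (0.40 log units; beyond the scatter) are its two steps.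

Compound 4 `CSc1ccc(/C=C(\C(=O)c2ccc(Cl)cc2)S(=O)(=O)Cc2ccc(Cl)cc2)cc1` differs from compound 2 in one place, with chloro in place of methyl on an aromatic carbon, para to a large group (chloro in place of methyl on an aromatic carbon), so 4-methylbenzyl becomes 4-chlorobenzyl. Going by the values given here, no measured step makes this change: all three measured compounds carry 4-methylbenzyl. The steps above, and no change at the digits printed from compound 1 to compound 3 (within the scatter), come from changes elsewhere, so they offer only a rough guide to size. None of them is large, so no step beyond the scatter is expected in this assay, starting from compound 2 at 10000 nM as the closest reference. The expected step is a 1.3-fold lower number from compound 2 to compound 4 (0.10 log units; within the scatter), an estimate with wide uncertainty. Compound 4 is expected near 8000 nM, with an estimated range of 2500 nM to 25000 nM as its span.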

Compound 4, concentration for 50% growth inhibition: 10000 nM
For compound 4 the middle estimate is 1.3-fold (0.10 log units) below the measured one; the measured number falls inside the stated range.
By their numbers in this assay, from the lowest: compounds 2 and 4 (each within the scatter of the next); then compounds 1 and 3 (each within the scatter of the next).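

Compounds 1, 2 and 3 all carry 4-methylbenzyl, so compound 4 is the first of those shown to vary this end of the molecule. In this assay chloro in place of methyl on this aromatic carbon makes no difference that can be read (no change at the digits printed from compound 2 to compound 4 (within the scatter)), so at this position the two groups cannot be told apart by growth inhibition in these cells. No measurement at hand helps to explain this result.

The compounds shown leave open whether a different group at this position, such as methoxy, an amine or a carboxylic acid, would shift the number beyond the scatter. They also leave open whether the same swap would read alike with the 4-bromophenyl of compound 1 or the 3-methylthiophen-2-yl of compound 3 in place of 4-(methylsulfanyl)phenyl.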